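This account rests on a few compounds, and the source may have more. Where it says the series, first, only, none or still open, it means among the compounds named here.

Measured compounds in an assay on CHO-K1 cells for displacement of a labelled ligand from prostaglandin E2 receptor EP1 subtype (Homo sapiens); on this read-out lower numbers stand for stronger inhibition and higher numbers for weaker inhibition:
compound 1 `Cc1cc(C(=O)Nc2cccc(F)c2)nn1Cc1cc(Cl)ccc1OCc1ccccc1` – 200 nM
compound 2 `Cc1cc(C(=O)NCc2ccccc2)nn1Cc1cc(Cl)ccc1OCc1ccccc1` – 39.8 nM
compound 3 `Cc1cc(NC(=O)OCc2ccccc2)nn1Cc1cc(Cl)ccc1OCc1ccccc1` – 79.4 nM

Compound 3 stands second highest of the three numbers. Its nearest neighbour is compound 2, with a 2.0-fold higher number from compound 2 to compound 3 (0.30 log units; within the scatter); the furthest is compound 1, with a 2.5-fold lower number from compound 1 to compound 3 (0.40 log units; beyond the scatter).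

Compound 4 `COC(=O)Nc1cc(C)n(Cc2cc(Cl)ccc2OCc2ccccc2)n1` differs from compound 3 by hydrogen in place of phenyl on a saturated chain carbon bound to an oxygen next to a carbonyl group. Among the compounds with values here, no measured step removes the aromatic ring from this arm. The step of a 5.0-fold lower number from compound 1 to compound 2 (0.70 log units; beyond the scatter) alters the group on the amide nitrogen and keeps an aromatic ring throughout; the step of a 2.0-fold higher number from compound 2 to compound 3 (0.30 log units; within the scatter) exchanges the linker while keeping the benzyl ring, and stays within the scatter. The two measured steps therefore show that the linker tolerates change but say nothing about losing the ring itself. Compound 4 is expected to give a somewhat higher number than compound 3, a 3.1-fold higher number from compound 3 to compound 4 (0.50 log units; beyond the scatter), with wide uncertainty. The estimate for compound 4 in this assay is 250 nM, in the range 60 nM to 1000 nM.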

Compound 4, half-maximal inhibitory concentration: 200 nM
Beside the measured number, compound 4's estimate is 1.3-fold (0.10 log units) above it; the range from low to high includes it.
By their numbers in this assay, from the lowest: compounds 2 and 3 (each within the scatter of the next); then compounds 1 and 4 (each within the scatter of the next).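

In this assay, within the data shown here, hydrogen in place of phenyl on a saturated chain carbon bound to an oxygen next to a carbonyl group gives a 2.5-fold higher number from compound 3 to compound 4 (0.40 log units; beyond the scatter); this is the only step here that removes the aromatic ring from this arm, and its size is modest. On an aromatic carbon, (methoxycarbonyl)amino in place of benzylcarbamoyl gives a 5.0-fold higher number from compound 2 to compound 4 (0.70 log units; beyond the scatter), whereas in place of (3-fluorophenyl)carbamoyl it gives no change at the digits printed from compound 1 to compound 4 (within the scatter), so the methoxycarbonyl arm and the 3-fluorophenyl amide arm cannot be told apart on this read-out. Nothing available explains these steps.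

Open, as far as these compounds go, is how the number moves between the methyl and benzyl ends of this arm, for example with an ethyl or a longer chain. Also open, from the compounds shown here alone, is whether an amine or a carboxylic acid on that aromatic carbon would fit the same trend.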